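From an Ester to a Hydroxyethyl Chain on the Core

A few compounds are considered here, and "the series" means these few. Any claim that something is new, unique, unknown or untested is made for them only; others in the source may bear on it.

Of the compounds shown here, three sharing one core have been measured in a functional assay for inhibition, with Homo sapiens as the target; on this read-out higher numbers stand for weaker inhibition and lower numbers for stronger inhibition. Compound 1 `O=C(O)COc1cccc(/C=C\c2nc(-c3ccccc3)c(-c3ccccc3)o2)c1` gives 180 nM. Compound 2 `CCOC(=O)/C(=C\c1cccc(OCC(=O)OC)c1)c1nc(-c2ccccc2)c(-c2ccccc2)o1` gives 2000 nM. Compound 3 `CCOC(=O)C(Cc1cccc(OCC(=O)O)c1)c1nc(-c2ccccc2)c(-c2ccccc2)o1` gives 120 nM, the lowest of the three numbers; its number and that of compound 1 sit within the usual scatter, so the two cannot be ranked, while compound 2 lies well beyond the scatter above both.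

Compound 4 `O=C(O)COc1cccc(CC(CCO)c2nc(-c3ccccc3)c(-c3ccccc3)o2)c1` has not yet been measured. It differs from compound 3 in one place: 2-hydroxyethyl in place of ethoxycarbonyl on a saturated chain carbon bound to an aromatic carbon and a saturated chain carbon. Going by the values given here, no pair of measured compounds differs by this change alone, so there is no measured step to lean on. Compound 2 also carries an ethoxycarbonyl, as compound 3 does, yet it differs from compound 3 in more than one place, so its weaker number cannot be tied to that group.

The change swaps one short chain for another on the same carbon. The step of a 1.8-fold higher number from compound 3 to compound 4 (0.26 log units; within the scatter) is therefore expected to be small, within the scatter or a slight weakening of inhibition. In this assay compound 4 is expected to give about 220 nM, with a likely range from 70 nM to 700 nM.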

Compound 4, half-maximal inhibitory concentration: 2920 nM
Compound 4: middle estimate off by 13-fold (1.12 log units), on the low side, outside the stated range (above it).
By their numbers in this assay, from the lowest: compounds 3 and 1 (each within the scatter of the next); then compounds 2 and 4 (each within the scatter of the next).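

In this assay, going by these compounds alone, putting 2-hydroxyethyl in place of ethoxycarbonyl on a saturated chain carbon bound to an aromatic carbon and a saturated chain carbon gives a 24-fold higher number from compound 3 to compound 4 (1.39 log units; beyond the scatter), the first measured step at this position, and it shows that inhibition here depends strongly on which group the carbon carries. The two groups are both short, uncharged and without a ring, so that likeness is no guide to how small a step will be. They still differ in several counted ways: ethoxycarbonyl has 5 heavy atoms, 1 double bond and 0 hydrogen-bond donors, while 2-hydroxyethyl has 3 heavy atoms, no double bond and 1 hydrogen-bond donor, and nothing at hand says which of these differences accounts for the step.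

The compounds shown leave open whether the ester as a whole matters or only part of it, since this single swap changes everything at once. A methyl ketone, a primary amide or a 2-methoxyethyl group on the same carbon would begin to separate these differences, and a longer chain ending in a hydroxyl would show whether the length of the chain counts.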